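The source may report more compounds than this note shows. Statements on the series, on what has been measured and on what is new or still open speak of the compounds shown alone.

Measured in an ADME assay on HUVEC cells (Homo sapiens) for inhibition, read by CCK-8 assay, with a stated time of 24 h, in the presence of a further agent that is not named here; on this read-out higher numbers stand for weaker inhibition and lower numbers for stronger inhibition:
Compound 1 `O=C1Nc2ccccc2/C1=C/c1ccc(-c2cn(-c3ccc(Cl)cc3)nn2)cc1`: 18200 nM
Compound 2 `N#Cc1cccc(-n2cc(-c3ccc(/C=C4\C(=O)Nc5ccccc54)cc3)nn2)c1`: > 20000 nM (a limit, not a number)

Compound 2 gives no number and stands only at the limit of > 20000 nM in this assay, at which 1 of the 2 values shown sits. Compound 3 `O=C1Nc2ccccc2/C1=C/c1ccc(-c2cn(-c3ccc(Cl)c(C(F)(F)F)c3)nn2)cc1` has 4-chloro-3-(trifluoromethyl)phenyl in place of 3-cyanophenyl on an aromatic nitrogen. Within the data shown here, the one measured step that bears on this change, at that same nitrogen, is an at least 1.0-fold higher number from compound 1 to compound 2 (0.04 log units; that floor lies within the scatter), and it sets no size. The expected change in this assay is therefore none beyond the scatter, with an estimated at least 1.3-fold lower number from compound 2 to compound 3 (0.12 log units; that floor lies within the scatter). Compound 3 is estimated at 15000 nM, with an expected range from 6000 nM to 30000 nM.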

Compound 3, half-maximal inhibitory concentration: > 20000 nM
Compound 3 gave a limit, no number; the forecaster's own chance of this, stated with the estimate: 45%; middle value at least 1.3-fold (0.12 log units) away from the limit.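

Compound 3, like compound 2, gives only a limit and not a number in this assay: the limit of > 20000 nM in this assay, at which 2 of the 3 values shown sit. Trifluoromethyl in place of hydrogen on an aromatic carbon gives an at least 1.0-fold higher number from compound 1 to compound 3 (0.04 log units; that floor lies within the scatter), so this change now has a floor, though not a size. The step between the two limits cannot be read.

On these data alone, how far compound 2 and compound 3 lie past the limit stays open. So does whether an amine or a carboxylic acid on this aromatic ring would give a readable number.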